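Changing the ring group on the amide of compound 3

The source may hold more compounds than are shown below. What is called first, only, known or untested is meant among the compounds shown, and "the series" means these compounds.

In an ADME assay on HepG2 cells (Homo sapiens) for cytotoxicity (on this read-out higher numbers stand for lower toxicity in this test and lower numbers for higher toxicity in this test), compound 1 (`O=C(N[C@H](/C=C/S(=O)(=O)c1ccccc1)CCc1ccccc1)c1cccc2cccnc12`) gives > 80000 nM as a limit of the assay, not a number. Compound 2 (`CCC[C@@H](/C=C/S(=O)(=O)c1ccccc1)NC(=O)c1cccc2cccnc12`) gives > 80000 nM as a limit too. Compound 3 (`O=C(N[C@H](/C=C/S(=O)(=O)c1ccccc1)CCc1ccccc1)c1cccc2nccnc12`) gives 39600 nM and is the only one of the three with an actual number.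

Compound 4 (`O=C(N[C@H](/C=C/S(=O)(=O)c1ccccc1)CCc1ccccc1)c1cccc2c1NCCC2`) has 1,2,3,4-tetrahydroquinolin-8-yl in place of quinoxalin-5-yl on a carbonyl carbon. Going by the values given here, the one measured change at this carbonyl carbon is an at least 2.0-fold lower number from compound 1 to compound 3 (0.30 log units; that floor lies within the scatter) and so offers no firm size for a swap here. The change on the chain, a step that the two limits leave unreadable from compound 1 to compound 2, says nothing about size. Any rise in this assay can be read only up to the limit of > 80000 nM in this assay, at which 2 of the 3 values shown sit, and a number may not appear at all.

The expected change is a 1.3-fold higher number from compound 3 to compound 4 (0.10 log units; within the scatter) and this estimate, pointing slightly higher, stays within the usual scatter. For compound 4 the estimate is 50000 nM with an expected range from 22000 nM to 80000 nM in this test.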

Compound 4, half-maximal cytotoxic concentration: > 160000 nM
Compound 4: no number, only a limit (the forecaster's own chance of this, stated with the estimate: 35%); at least 3.2-fold (0.50 log units) between middle value and limit.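

In this assay, going by these compounds alone, 1,2,3,4-tetrahydroquinolin-8-yl in place of quinoxalin-5-yl on this carbonyl carbon gives an at least 4.0-fold higher number from compound 3 to compound 4 (0.60 log units; beyond the scatter), the first step at this position that clears the usual scatter. For compound 4, the value > 160000 nM is a limit of the assay. The steps from compound 1 to compound 2 and from compound 1 to compound 4 cannot be read, so quinolin-8-yl and 1,2,3,4-tetrahydroquinolin-8-yl cannot be ranked against each other.

The entering group has a hydrogen-bond donor and a non-aromatic ring, while the leaving group has neither, and these compounds cannot show which of the two goes with the higher number. On these data alone, it also stays open whether a cyclohexyl group on this carbonyl carbon would shift the read-out in the same direction.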